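The compounds below may be only part of what the source reports. "The series", "measured", "known", "first", "only" and "open" are said of these compounds alone.

Working notes on the series. In a functional assay on MCF7 cells (Homo sapiens) for antiproliferative activity, read by MTT assay, with a stated time of 48 h (on this read-out lower numbers stand for stronger inhibition and higher numbers for weaker inhibition), compound 1 (`O=C(/C=C/c1ccc(O)c(O)c1)N1CCN(c2cccc(Cl)c2)CC1`) gives 1.34 ug/mL and compound 2 (`O=C(/C=C/c1ccc(O)c(O)c1)N1CCN(c2ccc([N+](=O)[O-])cc2)CC1`) gives 1.14 ug/mL. With only these two numbers available, compound 2 stands level with compound 1 within the scatter.

Compound 3 (`Cc1ccc(N2CCN(C(=O)/C=C/c3ccc(O)c(O)c3)CC2)c(C)c1`) keeps the shared core and carries 2,4-dimethylphenyl in place of 4-nitrophenyl on an amine nitrogen in a ring.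

Going by the values given here, the one measured step that bears on this change is a 1.2-fold lower number from compound 1 to compound 2 (0.07 log units; within the scatter), which also exchanges the group on that amine nitrogen. Among the compounds with values here, that step is small, but it is a single comparison, and no measured compound carries 2,4-dimethylphenyl. The data therefore give no direction for the new group, and no step beyond the scatter is expected in this assay. The estimated change is a 1.1-fold higher number from compound 2 to compound 3 (0.06 log units; within the scatter). For compound 3 the expected value is 1.3 ug/mL, with an estimated range from 0.6 ug/mL to 3 ug/mL. Within the data shown here, the range is kept wide, as it rests on only two measured compounds.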

Compound 3, half-maximal inhibitory concentration: 0.78 ug/mL
Compound 3: middle estimate off by 1.7-fold (0.22 log units), on the high side, and the stated range covers the measured number.
By their numbers in this assay, from the lowest: compounds 3, 2 and 1 (each within the scatter of the next).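

In this assay, the amine nitrogen in the ring now carries 2,4-dimethylphenyl, a group of 8 carbon atoms with 0 hydrogen-bond acceptors, in place of 4-nitrophenyl with its 2 hydrogen-bond acceptors, and the outcome is a 1.5-fold lower number from compound 2 to compound 3 (0.16 log units; within the scatter). Set against the 3-chlorophenyl group, the same new group gives a 1.7-fold lower number from compound 1 to compound 3 (0.24 log units; within the scatter), so the second exchange also stays inside the scatter. All three groups tried at this position, 3-chlorophenyl, 4-nitrophenyl and 2,4-dimethylphenyl, therefore stand level in this assay, and no measurement at hand offers an explanation for this flat picture.

On these data alone, it remains open whether the position stays this flat for groups other than a substituted phenyl, such as a benzyl group or a pyridine ring, or for a phenyl ring bearing a carboxylic acid or an amine. All three compounds also keep the shared core unchanged, so they leave open how the number responds to a change anywhere outside this position.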